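Moving a halogen on the phenol ring of a thiourea series

The source may hold more compounds than are shown below. What is called first, only, known or untested is meant among the compounds shown, and "the series" means these compounds.

Measured compounds:
compound 1, `COc1cc(CNC(=S)NC(CCc2ccc(C(C)(C)C)cc2)COC(=O)C(C)(C)C)ccc1O`, 36.5 nM
compound 2, `COc1cc(CNC(=S)NC(CCc2ccc(C(C)(C)C)cc2)COC(=O)C(C)(C)C)cc(Br)c1O`, 143 nM
compound 3, `COc1cc(CNC(=S)NC(CCc2ccc(C(C)(C)C)cc2)COC(=O)C(C)(C)C)cc(I)c1O`, 214 nM

In an assay on CHO cells for displacement of a labelled ligand from transient receptor potential cation channel subfamily V member 1 (Rattus norvegicus) (a lower number here means a stronger inhibitor, a higher number a weaker inhibitor), compound 3 gives the highest number of the three, though its gap to compound 2 is within the scatter, while a 5.9-fold higher number from compound 1 to compound 3 (0.77 log units; beyond the scatter) lies beyond it. Compound 4, `COc1cc(CNC(=S)NC(CCc2ccc(C(C)(C)C)cc2)COC(=O)C(C)(C)C)c(Br)cc1O`, changes the ring so that (2-bromo-4-hydroxy-5-methoxyphenyl in place of 4-hydroxy-3-iodo-5-methoxyphenyl on a saturated chain carbon bound to an amide-type nitrogen). Going by the values given here, two measured steps bear on this: a 1.5-fold higher number from compound 2 to compound 3 (0.18 log units; within the scatter) shows that bromo and iodo at the same place are hard to tell apart, and a 3.9-fold higher number from compound 1 to compound 2 (0.59 log units; beyond the scatter) shows that adding bromo there weakens binding. Among the compounds with values here, no measured pair shows what moving the halogen does. A number close to that of compound 2 is therefore expected, with wide uncertainty, that is a 1.9-fold lower number from compound 3 to compound 4 (0.29 log units; within the scatter). For compound 4 the estimate in this assay is 110 nM, ranging from 30 nM to 400 nM.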

Compound 4, inhibition constant: 75 nM
Estimate against measurement, compound 4: 1.5-fold (0.17 log units) above; measured number inside the range.
By their numbers in this assay, from the lowest: compound 1; then compounds 4, 2 and 3 (each within the scatter of the next, the first and the last beyond it).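

In this assay, going by these compounds alone, this is the first measured view of moving the bromo, and the two placements cannot be told apart: a 1.9-fold lower number from compound 2 to compound 4 (0.28 log units; within the scatter). The bromo of 2-bromo-4-hydroxy-5-methoxyphenyl still weakens binding compared with the ring that has no halogen, a 2.1-fold higher number from compound 1 to compound 4 (0.31 log units; beyond the scatter), while a 2.9-fold lower number from compound 3 to compound 4 (0.46 log units; beyond the scatter) changes both the halogen and its place, so neither change alone can be credited. No measurement shown explains these differences.

Still open, as far as these compounds go, is whether a chloro or a methyl group in place of that bromo would give a similar number.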